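Benzimidazole-Free Title: Cyclopentyl Replacing Methoxyphenyl at the Ring Nitrogen

A few compounds are considered here, and "the series" means these few. Any claim that something is new, unique, unknown or untested is made for them only; others in the source may bear on it.

Compound 1 `Cc1cccc(Cn2c(CN3CCN(C(=O)C4CCCCC4)CC3)nc3ccccc32)c1`: 31.9%
Compound 2 `COc1cccc(Cn2c(CN3CCN(C(=O)C4CC4)CC3)nc3ccccc32)c1`: 44.4%

In an assay on isolated protein for inhibition of aldehyde dehydrogenase 1A1 (Homo sapiens), read by spectrophotometry, tested at 10 uM (on this read-out lower numbers stand for less inhibition and higher numbers for more inhibition at the one concentration tested (going by the name of the read-out)), compound 2 stands highest of the two numbers measured, and compound 1 sits a step below it that lies beyond the usual scatter. Compound 3 `O=C(C1CC1)N1CCN(Cc2nc3ccccc3n2CC2CCCC2)CC1` differs from compound 2 by cyclopentyl in place of 3-methoxyphenyl on a saturated chain carbon bound to an aromatic nitrogen. Among the compounds with values here, no measured pair shows this kind of change, so nothing fixes its size; the account expects a modest drop rather than none, with a number 14.4 percentage points lower from compound 2 to compound 3 (beyond the scatter) as the step this expectation means. Compound 3 is therefore estimated at 30%, with a range from 10% to 52%.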

Compound 3, a percentage reported as inhibition, at one concentration (the size of the read-out at that concentration, not a potency): 44.5%
Beside the measured number, compound 3's estimate is 14.5 percentage points below it; the measured number falls inside the stated range.
By their numbers in this assay, from the lowest: compound 1; then compounds 2 and 3 (each within the scatter of the next).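

In this assay, cyclopentyl in place of 3-methoxyphenyl on a saturated chain carbon bound to an aromatic nitrogen gives a number 0.1 percentage points higher from compound 2 to compound 3 (within the scatter), the first step read at this position. In this one pair, neither the six-membered aromatic ring nor the methoxy oxygen is needed to hold the read-out at the one concentration tested. Nothing available explains why the two groups read alike. On these data alone, whether an amine or a carboxylic acid on the cyclopentyl ring would hold the read-out remains open. So does the effect of a longer chain in place of cyclopentylmethyl.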